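The compounds below may be only part of what the source reports. "The series", "measured", "known", "first", "only" and "open" are said of these compounds alone.

Compound 1 `OC(CCn1nc2c(Br)c(Br)c(Br)c(Br)c2n1)c1ccc(Br)cc1` is inactive in a functional assay on CCRF-CEM cells (Homo sapiens) for antiproliferative activity, read by MTT assay, with a stated time of 48 h, tested at 50 uM (on this read-out lower numbers stand for a stronger effect and higher numbers for a weaker effect at the one concentration tested), where compound 1 gives 0%. For the measured compounds named here, compound 2 `OC(CCn1nc2c(Br)c(Br)c(Br)c(Br)c2n1)c1ccccc1` gives 0%, so the only known step, no change at the digits printed from compound 1 to compound 2 (within the scatter), changes nothing at this one concentration. Compound 3 `OC(CCn1nc2c(Br)c(Br)c(Br)c(Br)c2n1)c1cccc(Br)c1` differs from compound 1 by 3-bromophenyl in place of 4-bromophenyl on a saturated chain carbon bound to an oxygen on a saturated carbon and a saturated chain carbon. That step does not directly match the known one, yet both bromine positions seen so far give no activity, so compound 3 is also expected to stay at the bottom of the scale, with an expected step of no change at the digits printed from compound 1 to compound 3 (within the scatter), giving an estimate of 0%, between 0% and 12%.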

Compound 3, a percentage reported as activity, at one concentration (the size of the read-out at that concentration, not a potency): 0%
Compound 3: the middle estimate sits on the measured number at the digits printed; low and high end bracket the measured number.
By their numbers in this assay, from the lowest: compounds 1, 2 and 3 (each within the scatter of the next).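

In this assay the swap of 4-bromophenyl for 3-bromophenyl gives no change at the digits printed from compound 1 to compound 3 (within the scatter) and so shows that moving the bromine on this ring leaves the read-out as it was at this one concentration. Adding bromo to the plain phenyl ring gives no change at the digits printed from compound 2 to compound 3 (within the scatter) and so shows the same for a 3-bromophenyl group as the earlier step showed for a 4-bromophenyl group. Nothing available explains this result.

From the compounds shown here alone, whether a group other than bromo on this ring, such as an amine or a carboxylic acid, would give a different read-out remains open. So does the effect of a longer chain in the linker to the shared core.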